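The compounds below may be only part of what the source reports. "The series", "measured", "known", "first", "only" and "open" are said of these compounds alone.

In a functional assay on MDA-MB-231 cells (Homo sapiens) for antiproliferative activity, read by sulforhodamine B assay, with a stated time of 48 h (on this read-out lower numbers stand for stronger inhibition and higher numbers for weaker inhibition), compound 3 (`Cc1ccc(C)c(NS(=O)(=O)c2ccc(N3CCNC3=O)cc2)c1`) gives 110 nM, the middle of three numbers: compound 2 (`COc1cc(NS(=O)(=O)c2ccc(N3CCNC3=O)cc2)cc(OC)c1OC`) stands lower at 45 nM and compound 1 (`CCc1cccc(NS(=O)(=O)c2ccc(N3CCNC3=O)cc2)c1`) higher at 1410 nM, both gaps beyond the scatter. Compound 4 (`COc1cccc(NS(=O)(=O)c2ccc(N3CCNC3=O)cc2)c1`) is still unmeasured. It differs from compound 3 by 3-methoxyphenyl in place of 2,5-dimethylphenyl on a sulfonamide nitrogen, with 3-methoxyphenyl in place of 2,5-dimethylphenyl on a sulfonamide nitrogen. Among the measured compounds shown here, the one measured step bearing on this place is large: a 13-fold lower number from compound 1 to compound 3 (1.11 log units; beyond the scatter). Going back towards a 3-substituted phenyl like that of compound 1 suggests a higher number, while the methoxy groups of compound 2, at 45 nM, argue against a full reversal. A moderate rise in this assay is therefore expected, estimated as a 2.9-fold higher number from compound 3 to compound 4 (0.46 log units; beyond the scatter). For compound 4 the estimate is 320 nM, with an expected range of 85 nM to 1200 nM.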

Compound 4, half-maximal inhibitory concentration: 730 nM
For compound 4 the middle estimate is 2.3-fold (0.36 log units) below the measured one; the range from low to high includes it.
By their numbers in this assay, from the lowest: compound 2; then compound 3; then compounds 4 and 1 (each within the scatter of the next).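

In this assay, 3-methoxyphenyl in place of 2,5-dimethylphenyl on a sulfonamide nitrogen gives a 6.6-fold higher number from compound 3 to compound 4 (0.82 log units; beyond the scatter) and so undoes much of what the earlier step to compound 3 had gained. Methoxy in place of ethyl on an aromatic carbon gives a 1.9-fold lower number from compound 1 to compound 4 (0.29 log units; within the scatter), which leaves these two groups indistinguishable on this read-out. Nothing available explains either result.

From the compounds shown here alone, what remains open is whether 2,5-dimethoxyphenyl would stand with compound 3 or with compound 4. Also open, going by these compounds, is how an amine or a carboxylic acid would fare on the same ring.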